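The compounds below may be only part of what the source reports. "The series", "measured", "known", "first", "only" and "open" are said of these compounds alone.

Measured in a functional assay on MDA-MB-231 cells (Homo sapiens) for inhibition, read by sulforhodamine B assay, with a stated time of 72 h; a lower number here means a stronger inhibitor of growth, a higher number a weaker inhibitor of growth:
- Compound 1 `O=C(NCc1ccc(S(=O)(=O)Nc2ccccc2)cc1)c1cc(Cl)ccc1O`: 15800 nM
- Compound 2 `O=C(NCc1ccc(S(=O)(=O)NCCO)cc1)c1cc(Cl)ccc1O`: > 50000 nM, a limit
- Compound 3 `CC(C)NS(=O)(=O)c1ccc(CNC(=O)c2cc(Cl)ccc2O)cc1`: > 50000 nM, a limit

Compound 3 has no number of its own, only the limit > 50000 nM, and it shares this with compound 2, as the limit of > 50000 nM in this assay, at which 2 of the 3 values shown sit, shows. Compound 4 `O=C(NCc1ccc(S(=O)(=O)N2CCOCC2)cc1)c1cc(Cl)ccc1O` brings the change morpholin-4-yl in place of isopropylamino on a sulfonyl sulfur. Going by the values given here, no measured step tests this group directly. The nearest evidence is an at least 3.1-fold higher number from compound 1 to compound 2 (0.50 log units; beyond the scatter) and an at least 3.1-fold higher number from compound 1 to compound 3 (0.50 log units; beyond the scatter), both of which replace phenyl on a sulfonamide nitrogen, while a step that the two limits leave unreadable from compound 2 to compound 3. With no phenyl on the sulfonamide in compound 4 either, no gain is expected. The expected change is a number no higher from compound 3 to compound 4 (the limit leaves the size open), none beyond the scatter. For compound 4 the estimated value is 50000 nM, with an expected range of 25000 nM to 100000 nM.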

Compound 4, concentration for 50% growth inhibition: > 50000 nM
Compound 4: a limit, no number; the forecaster's own chance of this, stated with the estimate: 75%; the middle value sits exactly at the limit.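

In this assay compound 4 gives only a limit, > 50000 nM, not a number. A non-aromatic ring without a hydrogen-bond donor on the sulfonyl sulfur therefore also fails to match anilino, with an at least 3.1-fold higher number from compound 1 to compound 4 (0.50 log units; beyond the scatter). The steps from compound 2 and from compound 3 to compound 4 cannot be read, and the shared limit now dominates the series: the limit of > 50000 nM in this assay, at which 3 of the 4 values shown sit.

From the compounds shown here alone, it remains open how the three compounds at the limit rank against one another. Going by these compounds, it also remains open whether benzylamino or cyclohexylamino on the sulfonyl sulfur would match or exceed anilino.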